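Working notes: compound 3 in the glucose-6-phosphatase series

The source may hold more compounds than are shown below. What is called first, only, known or untested is meant among the compounds shown, and "the series" means these compounds.

Measured so far:
compound 1 `CSc1c(C#N)c(N)c(C#N)c(-c2ccccc2)c1-c1ccccc1`: 7.4%
compound 2 `COc1ccc(-c2c(C#N)c(N)c(C#N)c(SC)c2-c2ccccc2)cc1`: 6.8%

In an assay on isolated protein for inhibition of glucose-6-phosphatase catalytic subunit 1 (Homo sapiens), tested at 100 uM (on this read-out lower numbers stand for less inhibition and higher numbers for more inhibition at the one concentration tested (going by the name of the read-out)), compound 1 gives 7.4% and compound 2 gives 6.8%. Of the two numbers shown, compound 2 sits at the lower end, but the step of a number 0.6 percentage points lower from compound 1 to compound 2 (within the scatter) is within the scatter, so no ranking of the two follows. Compound 3 `CSc1c(C#N)c(N)c(C#N)c(Cc2ccccc2)c1-c1ccccc1` has not been measured in this assay. It differs from compound 2 by benzyl in place of 4-methoxyphenyl on an aromatic carbon. For the measured compounds named here, no measured step bears directly on this change: the only step known, a number 0.6 percentage points lower from compound 1 to compound 2 (within the scatter), concerns a methoxy alone and was within the scatter. Both known values are small and close to each other, so nothing in the series points to a step beyond the scatter for compound 3. Compound 3 is expected at 7%, with a range from 0% to 20%. The step this estimate means, a number 0.2 percentage points higher from compound 2 to compound 3 (within the scatter), is expected to be none beyond the scatter.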

Compound 3, a percentage reported as inhibition, at one concentration (the size of the read-out at that concentration, not a potency): 24.5%
Beside the measured number, compound 3's estimate is 17.5 percentage points below it, outside the stated range (above it).
By their numbers in this assay, from the lowest: compounds 2 and 1 (each within the scatter of the next); then compound 3.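

In this assay, the aromatic carbon ortho to a cyano group and ortho to a phenyl group now shows a step beyond the scatter: a number 17.1 percentage points higher from compound 1 to compound 3 (beyond the scatter), with benzyl in place of phenyl. Against the methoxy-bearing aryl group the picture is the same, a number 17.7 percentage points higher from compound 2 to compound 3 (beyond the scatter), while the methoxy alone had given only a number 0.6 percentage points lower from compound 1 to compound 2 (within the scatter), so among these compounds the change to benzyl moves the number and the methoxy does not. No measurement available here explains the rise.

As far as these compounds go, whether the gain stays with benzyl or grows, holds or fades with a longer chain such as 2-phenylethyl remains open. Also open, from the compounds shown here alone, is how a non-aromatic group at this position, such as an amine or a carboxylic acid, would read out.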